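The source may hold more compounds than are shown below. What is called first, only, known or untested is meant among the compounds shown, and "the series" means these compounds.

Of the compounds shown here, two of a shared core have been measured so far. Compound 1, `CCCCCCCCC[C@]1(CO)NC[C@@H](O)[C@@H]1O`, carries a long chain on the core, while compound 2, `C[C@]1(CO)NC[C@@H](O)[C@@H]1O`, carries only a methyl at the same place. In an assay on isolated protein for inhibition of alpha-galactosidase (Coffea arabica), tested at 1000 uM (a higher number here means more inhibition at the concentration tested (going by the name of the read-out), a lower number less inhibition), compound 1 gives 2.5%. In this assay compound 2 gives 0.6%. These two numbers lie within the usual scatter of each other, so on the present data compound 2 stands level with compound 1, and neither chain length has set itself apart; both readings sit near the floor of the read-out.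

Compound 3, `CCCC[C@]1(CO)NC[C@@H](O)[C@@H]1O`, has not yet been measured. It differs from compound 2 in one place: propyl in place of hydrogen on a saturated chain carbon bound to a saturated ring carbon. For the measured compounds named here, since no measured pair with a comparable difference exists here, nothing beyond the two numbers above can guide the expectation.

Given that compound 1 and compound 2 differ only within the scatter, the step of a number 0.9 percentage points higher from compound 2 to compound 3 (within the scatter) is expected to stay within the scatter as well. Compound 3 is estimated to give 1.5% in this assay, within a range from 0% to 8%.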

Compound 3, a percentage reported as inhibition, at one concentration (the size of the read-out at that concentration, not a potency): 4.6%
For compound 3 the middle estimate is 3.1 percentage points below the measured one; measured number inside the range.
By their numbers in this assay, from the lowest: compounds 2, 1 and 3 (each within the scatter of the next).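

In this assay, a middle chain length now joins the two earlier ends of the series, and it does not set itself apart from the methyl of compound 2: propyl in place of hydrogen on a saturated chain carbon bound to a saturated ring carbon gives a number 4 percentage points higher from compound 2 to compound 3 (within the scatter). Against the long chain the picture is the same, with hydrogen in place of pentyl on a saturated chain carbon, four bonds along the chain from a saturated ring carbon, giving a number 2.1 percentage points higher from compound 1 to compound 3 (within the scatter), so across these three compounds the length of the chain at this position shows no readable effect on a read-out that stays near its floor. Nothing at hand bears on why the readings lie so close together.

As far as these compounds go, it remains open whether any group at this position can lift the reading clear of the floor, as only plain carbon chains appear here; a phenyl ring, an amine or a carboxylic acid at the end of the chain would test that. From the compounds shown here alone, all three numbers also come from a single enzyme, so whether the same flat picture holds for any other enzyme stays open.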